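Cytotoxicity notes on the side-chain ester variants

The source may report more compounds than this note shows. Statements on the series, on what has been measured and on what is new or still open speak of the compounds shown alone.

Compound 3 `COC[C@H]1C[C@@](CC(C)C)(C(=O)O)N(C(=O)c2ccc(C(C)(C)C)c(OC)c2)[C@H]1COC(C)=O` stands in an ADME assay on Huh-5-2 cells (Homo sapiens) for cytotoxicity, with a stated time of 3 days (a lower number here means that less compound is tolerated, a higher number that more compound is tolerated), only at a limit: compound 3 gives > 120000 nM. Compound 1 `COC[C@H]1C[C@@](CC(C)C)(C(=O)O)N(C(=O)c2ccc(C(C)(C)C)c(OC)c2)[C@H]1[C@H]1COC(C)(C)O1` is likewise known only as a limit, with compound 1 giving > 120000 nM. Compound 2 `COC[C@H]1C[C@@](CC(C)C)(C(=O)O)N(C(=O)c2ccc(C(C)(C)C)c(OC)c2)[C@H]1[C@H]1COC(=O)O1` also reaches only a limit, compound 2 giving > 120000 nM. Among the measured compounds shown here, all three values therefore sit at the limit of > 120000 nM in this assay, at which 3 of the 3 values shown sit, and the three steps among them, a step that the two limits leave unreadable from compound 1 to compound 2, a step that the two limits leave unreadable from compound 1 to compound 3 and a step that the two limits leave unreadable from compound 2 to compound 3, are left without a readable size; they show only that no measured change in this part of the core lifted the value into the readable range.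

Compound 4 `COC[C@H]1C[C@@](CC(C)C)(C(=O)O)N(C(=O)c2ccc(C(C)(C)C)c(OC)c2)[C@H]1COC(=O)OC` differs from compound 3 by methoxy in place of methyl on a carbonyl carbon. For the measured compounds named here, no measured step bears on this change with a readable size, and every measured variant of the side chain sits at the same limit. The expectation for compound 4 in this assay is therefore no step beyond the scatter, a number no higher from compound 3 to compound 4 (the limit leaves the size open), with a further limit the most likely outcome. Compound 4 is estimated at 120000 nM, within 60000 nM to 240000 nM.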

Compound 4, half-maximal cytotoxic concentration: > 120000 nM
Compound 4: a limit, no number; the forecaster's own chance of this, stated with the estimate: 85%; the middle value sits exactly at the limit.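

In this assay compound 4 gives > 120000 nM, which is a limit and not a number. The steps linking compound 4 to compound 1, compound 2 and compound 3 therefore cannot be read: the limit of > 120000 nM in this assay, at which 4 of the 4 values shown sit.

The compounds shown leave open whether these side-chain variants differ at all in this assay.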